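Triazole N-aryl variation in a cinnamic acid series

The source may report more compounds than this note shows. Statements on the series, on what has been measured and on what is new or still open speak of the compounds shown alone.

Measured so far:
- compound 1 `COc1ccc(/C=C\C(=O)O)c(OCc2cn(-c3ccccc3F)nn2)c1CC=C(C)C`: 14500 nM
- compound 2 `COc1ccc(/C=C\C(=O)O)c(OCc2cn(-c3ccccc3I)nn2)c1CC=C(C)C`: "not determined" (no result reported)
- compound 3 `COc1ccc(/C=C\C(=O)O)c(OCc2cn(-c3ccc(C#N)cc3)nn2)c1CC=C(C)C`: 32000 nM

In a functional assay on COLO 205 cells (Homo sapiens) for cytotoxicity, read by MTT assay, with a stated time of 24 h (on this read-out lower numbers stand for stronger inhibition and higher numbers for weaker inhibition), compound 3 gives 32000 nM, the highest of the two numbers; compound 1 stands nearest with a 2.2-fold higher number from compound 1 to compound 3 (0.34 log units; beyond the scatter). Compound 4 `COc1ccc(/C=C\C(=O)O)c(OCc2cn(-c3ccccc3C#N)nn2)c1CC=C(C)C` is not yet measured; it differs from compound 3 by 2-cyanophenyl in place of 4-cyanophenyl on an aromatic nitrogen. Among the measured compounds shown here, the only measured step that bears on this change is the modest one from compound 1 to compound 3, where the 2-fluorophenyl of compound 1 gave the lower number. On that slender basis the step is expected to be small, at most modest, toward a lower number, estimated as a 1.6-fold lower number from compound 3 to compound 4 (0.20 log units; within the scatter). Compound 4 is expected to give 20000 nM in this assay, within 8000 nM to 50000 nM.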

Compound 4, half-maximal inhibitory concentration: 3200 nM
Compound 4: middle estimate off by 6.3-fold (0.80 log units), on the high side; the whole stated range lies above it.
By their numbers in this assay, from the lowest: compound 4; then compound 1; then compound 3.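

In this assay, the step from 4-cyanophenyl to 2-cyanophenyl, with the same atoms joined differently, gives a 10-fold lower number from compound 3 to compound 4 (1.00 log units; beyond the scatter), so where the nitrile sits on this phenyl ring matters, which compound 1 and compound 3 could not show apart from the change of group. With the group at the same ring place, cyano in place of fluoro gives a 4.5-fold lower number from compound 1 to compound 4 (0.66 log units; beyond the scatter), so the group itself also counts. No measurement here explains either step.

Compound 2 has no reported result, so the iodo group cannot be placed in this order. On these data alone, how a methoxy group or an amine would compare with the nitrile on this ring remains open.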